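Toxicity notes: the step from compound 1 to compound 4

A few compounds are considered here, and "the series" means these few. Any claim that something is new, unique, unknown or untested is made for them only; others in the source may bear on it.

In a toxicity assay (LMTK cells) for cytotoxicity, with Mus musculus as the target, read by MTT assay, with a stated time of 72 h (a lower number here means a stronger inhibitor, a higher number a weaker inhibitor), compound 1 (`Cc1c(C)c2c(c(C)c1OC(=O)CCC(=O)O)CCC(C)(C(=O)NC1CC(C)(C)N([O])C(C)(C)C1)O2`) reads > 300000 nM as a limit, not a number. Compound 3 (`CC1(C)CC(CNC(=O)CCC(=O)O)C(C)(C)N1[O]`) reads > 300000 nM as a limit too. Among the measured compounds shown here, compound 2 (`Cc1c(C)c2c(c(C)c1O)CCC(C)(C(=O)NC1CC(C)(C)N([O])C(C)(C)C1)O2`) gives 252000 nM as the one true number. Compound 1 thus stands at the limit of > 300000 nM in this assay, at which 2 of the 3 values shown sit, and has no exact rank.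

The change to compound 4 (`Cc1c(C)c2c(c(C)c1OC(=O)CCC(=O)O)CCC(C)(C(=O)O)O2`) is one oxygen atom in place of a group of 12 heavy atoms (9 carbon, 2 nitrogen, 1 oxygen; one six-membered non-aromatic ring with 1 hetero atom), on a carbonyl carbon with hydroxy entering on a carbonyl carbon. For the measured compounds named here, the one measured step is an at least 1.1-fold lower number from compound 1 to compound 2 (0.07 log units; that floor lies within the scatter) and it sits at another place, so no step beyond the scatter is expected in this assay for this change. The expected outcome is a step that the limit leaves unreadable from compound 1 to compound 4 and no more. For compound 4 the estimate is 400000 nM (from 200000 nM to 1000000 nM).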

Compound 4, half-maximal inhibitory concentration: > 300000 nM
Compound 4: no number, only a limit; the forecaster's own chance of this, stated with the estimate: 80%; the middle value is on the limit's open side.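

In this assay compound 4 reads > 300000 nM, a limit and not a number. Compound 1 is also a limit, so no step can be read between compound 1 and compound 4. The compounds shown leave open how far compound 1, compound 3 and compound 4 lie past the shared limit: the limit of > 300000 nM in this assay, at which 3 of the 4 values shown sit.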